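Hydrazone Aryl Substituent Series: Chloro Analogue Estimate

A few compounds are considered here, and "the series" means these few. Any claim that something is new, unique, unknown or untested is made for them only; others in the source may bear on it.

Measured compounds in a functional assay on UACC-62 cells (Homo sapiens) for inhibition, read by sulforhodamine B assay, with a stated time of 48 h; on this read-out lower numbers stand for stronger inhibition of growth and higher numbers for weaker inhibition of growth:
Compound 1 `CC1=CC[C@H](C(C)(C)NC(=S)N/N=C/c2ccccc2)CC1`: 31600 nM.
Compound 2 `CC1=CC[C@H](C(C)(C)NC(=S)N/N=C/c2ccccc2O)CC1`: 2800 nM.
Compound 3 `CC1=CC[C@H](C(C)(C)NC(=S)N/N=C/c2ccc(F)cc2)CC1`: reported only as a limit, > 100000 nM.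

Compound 3 stands at the top of the measured range, since its value is the assay limit of > 100000 nM in this assay, at which 1 of the 3 values shown sits, rather than a number. Compound 4 `CC1=CC[C@H](C(C)(C)NC(=S)N/N=C/c2ccccc2Cl)CC1` differs from it by 2-chlorophenyl in place of 4-fluorophenyl on a carbon with a double bond to nitrogen. The steps bearing on this change are an at least 3.1-fold higher number from compound 1 to compound 3 (0.50 log units; beyond the scatter) and an at least 35-fold higher number from compound 2 to compound 3 (1.55 log units; beyond the scatter), both reaching compound 3 from lower numbers; compound 2, with 2-hydroxyphenyl, gives the lowest number in the set. For compound 4 a lower number than the limit of compound 3 is therefore expected, the estimated step being an at least 6.6-fold lower number from compound 3 to compound 4 (0.82 log units; beyond the scatter). Compound 4 is estimated at 15000 nM, within 3000 nM to 100000 nM.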

Compound 4, concentration for 50% growth inhibition: 19300 nM
Compound 4: middle estimate off by 1.3-fold (0.11 log units), on the low side, within the range that was stated.
By their numbers in this assay, from the lowest: compound 2; then compounds 4 and 1 (each within the scatter of the next). At a limit, above all of these: compound 3.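

The chloro group alone stays within the scatter in this assay (a 1.6-fold lower number from compound 1 to compound 4 (0.21 log units; within the scatter)), so 2-chlorophenyl does not share the gain seen with 2-hydroxyphenyl. Chloro in place of hydroxy loses much of that gain (a 6.9-fold higher number from compound 2 to compound 4 (0.84 log units; beyond the scatter)). The step from 4-fluorophenyl (an at least 5.1-fold lower number from compound 3 to compound 4 (0.71 log units; beyond the scatter)) is only a bound and rests on the limit of compound 3: the limit of > 100000 nM in this assay, at which 1 of the 4 values shown sits.

Open, from the compounds shown here alone, is whether methoxy or an amine in place of hydroxy keeps the number of compound 2. Also open, going by these compounds, is whether 2-fluorophenyl or 4-chlorophenyl would separate the halogen from its placement.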